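The compounds below may be only part of what the source reports. "The series", "measured", "known", "first", "only" and "open" are said of these compounds alone.

Working notes on the series. In an assay on isolated protein for inhibition of tyrosine-protein phosphatase non-receptor type 13 (Homo sapiens), read by spectrophotometry (a lower number here means a stronger inhibitor, a higher number a weaker inhibitor), compound 1 `Oc1c(-c2ccccc2)cccc1C(O)(C(F)(F)F)C(F)(F)F` gives 449000 nM. Compound 3 `Oc1c(C(O)(C(F)(F)F)C(F)(F)F)ccc2ccccc12` returns only a limit in this assay, > 500000 nM. Compound 2 `O=C(COc1ccc2cc(C(O)(C(F)(F)F)C(F)(F)F)c(O)cc2c1)NCc1ccc(F)cc1` likewise returns only a limit in this assay, > 20000 nM, so compound 2 stands at a limit and carries no number of its own. Among the three values shown, one other also sits at a limit (the limit of > 500000 nM in this assay, at which 1 of the 3 values shown sits). Compound 4 `O=C(COc1ccc2cc(C(O)(C(F)(F)F)C(F)(F)F)c(O)cc2c1)NCc1ccccc1` differs from compound 2 by hydrogen in place of fluoro on an aromatic carbon. Going by the values given here, no measured pair tracks such a change, so no step beyond the usual scatter is expected in either direction. Compound 4 is therefore estimated at 40000 nM, within 15000 nM to 120000 nM. The estimated step is a step that the limit leaves unreadable from compound 2 to compound 4, most likely again reported as a limit.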

Compound 4, half-maximal inhibitory concentration: > 20000 nM
Compound 4: a limit, no number; the forecaster's own chance of this, stated with the estimate: 80%; the middle value does not contradict the limit.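

Compound 2 and compound 4 both return only limits, so the step between them cannot be read. The compounds shown leave open what the change from 4-fluorobenzyl to benzyl does to inhibition.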